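This account rests on a few compounds, and the source may have more. Where it says the series, first, only, none or still open, it means among the compounds named here.

Three compounds of one shared core have been compared in an in vitro assay on 293-EBNA cells for binding affinity to corticotropin-releasing factor receptor 1 (Homo sapiens); a lower number here means a stronger inhibitor, a higher number a weaker inhibitor. Compound 1 `CCCCN(CC)c1nc(C)nc2c1nnn2-c1c(C)cc(C)cc1C` gives 27.5 nM in this assay. Compound 2 `CCCC(CCC)Nc1nc(C)nc2c1nnn2-c1ccc(Br)cc1Br` gives 0.8 nM. Compound 3 `COCC(COC)Nc1nc(C)nc2c1nnn2-c1ccc(C(C)C)cc1Br` gives 10.3 nM, which is the second highest of the three numbers: its nearest neighbour is compound 1, with a higher number beyond the scatter, and its furthest is compound 2, with a lower number well beyond the scatter.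

The next compound, compound 4 `CCC(CC)Oc1nc(C)nc2c1nnn2-c1ccc(C(C)C)cc1Br`, is built from compound 3 by a single change: (pentan-3-yl)oxy in place of (2-methoxy-1-(methoxymethyl)ethyl)amino on an aromatic carbon. The group that leaves carries one hydrogen-bond donor and three acceptors; the group that enters carries no donor and one acceptor, and it is a plain branched chain of the kind that, in compound 2, sits on an amino group.

For the measured compounds named here, no pair of measured compounds differs in only this place, so the step cannot be read from the data directly. Because compound 2 gives 0.8 nM with a branched chain on the same side of the core, a modest downward step is expected, though one that may stay within the scatter; the expected step from compound 3 to compound 4 is a 2.1-fold lower number from compound 3 to compound 4 (0.31 log units; beyond the scatter). Compound 4 is accordingly estimated at 5 nM, within a range from 1.5 nM to 20 nM.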

Compound 4, inhibition constant: 1.9 nM
Estimate against measurement, compound 4: 2.6-fold (0.42 log units) above; the range from low to high includes it.
By their numbers in this assay, from the lowest: compound 2; then compound 4; then compound 3; then compound 1.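

For the compounds shown here, the step gives the first direct reading at this position: in this assay, (pentan-3-yl)oxy in place of (2-methoxy-1-(methoxymethyl)ethyl)amino on this aromatic carbon gives a 5.4-fold lower number from compound 3 to compound 4 (0.73 log units; beyond the scatter). It shows that, with the rest of compound 3 unchanged, this position accepts a group with no hydrogen-bond donor and a single acceptor, and that neither the amino hydrogen nor the two methoxy groups of the leaving group are needed to keep the number low in this assay. Nothing measured here explains the size of the step, which remains an observation without a stated cause.

The change replaces the linking atom and the chain at once, so the compounds shown do not separate the contribution of the oxygen link from that of the plain pentan-3-yl chain. That question stays open for (pentan-3-yl)amino and (2-methoxy-1-(methoxymethyl)ethyl)oxy on the same core, and the compounds shown also say nothing about how a cyclopentyloxy group or a longer ether chain would behave at this position.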